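A few compounds are considered here, and "the series" means these few. Any claim that something is new, unique, unknown or untested is made for them only; others in the source may bear on it.

Working notes on the series of arylidene lactams carrying a 2,6-dichlorophenyl group on the ring nitrogen.

Compound 1 `O=C1/C(=C\c2ccc(O)cc2)c2ccccc2N1c1c(Cl)cccc1Cl` is the reference point. In a functional assay on L132 cells (Homo sapiens) for cytotoxicity, read by MTT assay, with a stated time of 72 h (a higher number here means that more compound is needed for the effect, a lower number that less compound is needed), compound 1 gives 30 ug/mL. Within the data shown here, compound 3 `O=C1/C(=C\c2cccc(Oc3ccccc3)c2)c2ccccc2N1c1c(Cl)cccc1Cl` is the only other member with a number: in this assay compound 3 gives 24 ug/mL, and the two numbers lie within the scatter of each other, so no difference between compound 1 and compound 3 can be read from them. Compound 2 `Cc1ccc2nc(Cl)c(/C=C3\C(=O)N(c4c(Cl)cccc4Cl)c4ccccc43)cc2c1` carries a fused bicyclic arylidene group; in this assay compound 2 is recorded as "not determined" (no result reported), so it adds nothing to the comparison.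

Compound 4 `O=C1/C(=C\c2ccccc2Cl)c2ccccc2N1c1c(Cl)cccc1Cl` differs from compound 1 in one place: 2-chlorophenyl in place of 4-hydroxyphenyl on a double-bonded chain carbon bound to a double-bonded ring carbon. Among the measured compounds shown here, no measured pair isolates a change of this kind, so there is nothing to scale the step against. Given that compound 1 at 30 ug/mL and compound 3 at 24 ug/mL sit close together despite different arylidene groups, the expectation is a step from compound 1 to compound 4 of no change at the digits printed from compound 1 to compound 4 (within the scatter), not beyond the scatter in either direction. Compound 4 is therefore estimated at 30 ug/mL in this assay, within a range of 15 ug/mL to 60 ug/mL.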

Compound 4, concentration for half-maximal effect: > 100 ug/mL
Compound 4: only a limit was reported; the forecaster's own chance of this, stated with the estimate: 10%; middle value at least 3.3-fold (0.52 log units) from the limit.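

The earlier numbers gave no sign that the group on the double-bonded chain carbon bound to a double-bonded ring carbon matters for cytotoxicity, but in this assay replacing 4-hydroxyphenyl with 2-chlorophenyl there gives an at least 3.3-fold higher number from compound 1 to compound 4 (0.52 log units; beyond the scatter). For compound 4 the reading is a limit of the assay and not a number: the limit of > 100 ug/mL in this assay, at which 1 of the 4 values shown sits. The step combines more than one difference, since 4-hydroxyphenyl carries 1 hydrogen-bond donor and 1 hydrogen-bond acceptor, 2-chlorophenyl carries none, and chlorine enters.

Among the compounds shown, none separates the loss of the hydroxyl from the arrival of the chlorine, so the step cannot be assigned to either. A plain phenyl or a 4-aminophenyl group at this place would bear on that question.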